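A few compounds are considered here, and "the series" means these few. Any claim that something is new, unique, unknown or untested is made for them only; others in the source may bear on it.

Working notes on the series.

Compound 1 `COc1cc(/C=C/C(=O)c2sc(Nc3cccc(Cl)c3)nc2C)cc(OC)c1OC` in a functional assay on NCI-H460 cells (Homo sapiens) for cytotoxicity, read by MTT assay (a lower number here means a stronger inhibitor, a higher number a weaker inhibitor), gives > 25000 nM, which is a limit of the assay rather than a number. Compound 3 `COc1cc(/C=C/C(=O)c2sc(Nc3ccc(Cl)c(Cl)c3)nc2C)cc(OC)c1OC` differs from it by chloro in place of hydrogen on an aromatic carbon and in this assay gives > 25000 nM, again a limit. The step that the two limits leave unreadable from compound 1 to compound 3 therefore cannot be read, since (the limit of > 25000 nM in this assay, at which 3 of the 3 values shown sit).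

Compound 2 `Cc1nc(Nc2ccccc2)sc1C(=O)/C=C/c1ccccc1` in this assay gives > 25000 nM, also a limit. The difference between the cores of compound 1 and compound 2 is not broken down here.

Compound 4 `Cc1nc(Nc2ccccc2)sc1C(=O)/C=C/c1ccccc1Cl` differs from compound 2 by chloro in place of hydrogen on an aromatic carbon. This is the same kind of change as from compound 1 to compound 3, but the place differs: there the new chloro sat ortho to a chloro group and para to a large group; here it sits ortho to a large group.

The step that the limit leaves unreadable from compound 2 to compound 4 is expected to leave compound 4 at the limit, because the limit of > 25000 nM in this assay, at which 3 of the 3 values shown sit, holds for every value seen. Compound 4 is estimated at 40000 nM in this assay, between 10000 nM and 150000 nM.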

Compound 4, half-maximal inhibitory concentration: > 25000 nM
Compound 4 ended at the assay's limit; the forecaster's own chance of this, stated with the estimate: 75%; the middle value lies beyond the limit too.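

No step can be read from compound 2 to compound 4, since both values are limits: the limit of > 25000 nM in this assay, at which 4 of the 4 values shown sit. The compounds shown leave open which structural change, if any, would give a number rather than a limit in this assay for this series.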